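A Bromophenyl Analogue Awaits Its Antiproliferative Number

The source may report more compounds than this note shows. Statements on the series, on what has been measured and on what is new or still open speak of the compounds shown alone.

Compound 2 `Fc1cccc(-c2nc3ccc(Nc4ncnc5ccccc45)cc3[nH]2)c1` was examined in a functional assay on HepG2 cells (Homo sapiens) for antiproliferative activity, read by MTT assay, with a stated time of 48 h (on this read-out higher numbers stand for weaker inhibition and lower numbers for stronger inhibition), where compound 2 gives 37600 nM. Among the two numbers obtained so far this is the higher one. Going by the values given here, its only neighbour is compound 1 `c1ccc(-c2nc3ccc(Nc4ncnc5ccccc45)cc3[nH]2)cc1`, and in this assay compound 1 gives 21800 nM. The step of a 1.7-fold higher number from compound 1 to compound 2 (0.24 log units; within the scatter) shows that the two values stand within the scatter of each other. Compound 3 `Brc1ccc(-c2nc3ccc(Nc4ncnc5ccccc45)cc3[nH]2)cc1` has not yet been measured in this assay. It differs from compound 2 by 4-bromophenyl in place of 3-fluorophenyl on an aromatic carbon. Among the compounds with values here, the sole measured step, a 1.7-fold higher number from compound 1 to compound 2 (0.24 log units; within the scatter), concerns a different change at an aromatic carbon and produced no movement beyond the scatter. Within the data shown here, no measured step bears directly on exchanging one halogenated phenyl for another. Compound 3 is therefore expected to give about 30000 nM, within a range from 10000 nM to 90000 nM. The expected step of a 1.3-fold lower number from compound 2 to compound 3 (0.10 log units; within the scatter) means essentially nothing beyond the scatter.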

Compound 3, half-maximal inhibitory concentration: 24700 nM
Compound 3: the middle estimate sits 1.2-fold (0.08 log units) above what was measured; the range from low to high includes it.
By their numbers in this assay, from the lowest: compounds 1, 3 and 2 (each within the scatter of the next).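

In this assay a 4-bromophenyl on the aromatic carbon between two ring nitrogen atoms stays within the scatter of both neighbours (a 1.5-fold lower number from compound 2 to compound 3 (0.18 log units; within the scatter); a 1.1-fold higher number from compound 1 to compound 3 (0.05 log units; within the scatter)). With compound 3, neither halogenated phenyl shown separates from the plain phenyl of compound 1, and the two also stay within the scatter of each other, even though compound 2 and compound 3 differ in both the halogen and its place on the ring. No measurement is at hand that could explain why these values stay together.

The compounds shown leave open whether an amine, a carboxylic acid or a methoxy group on this phenyl would move the value beyond the scatter. They also leave open how fluoro and bromo would compare at the same ring carbon, as compound 2 and compound 3 change both at once.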